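The source may hold more compounds than are shown below. What is called first, only, known or untested is meant among the compounds shown, and "the series" means these compounds.

Measured in an ADME assay on HCT-116 cells (Homo sapiens) for antiproliferative activity; on this read-out lower numbers stand for stronger inhibition and higher numbers for weaker inhibition:
- Compound 1 `Cc1cc(OCc2cccc(C#N)c2)ccc1Cl`: 45000 nM
- Compound 2 `COc1ccc(C(N)=O)cc1COc1ccc(Cl)c(C)c1`: > 50000 nM

Compound 2 gives > 50000 nM, which is a limit of this assay and not a number. Compound 3 `COc1ccc(C#N)cc1COc1ccc(Cl)c(C)c1` is still to be measured. It has cyano in place of carbamoyl on an aromatic carbon, para to a methoxy group: cyano in place of carbamoyl on an aromatic carbon. Among the compounds with values here, no measured step shows this change. The expectation rests on compound 1, which also carries a cyano on an aromatic carbon and gives 45000 nM. The expected step is small and toward stronger inhibition, and it may not exceed the usual scatter: an at least 1.5-fold lower number from compound 2 to compound 3 (0.18 log units; that floor lies within the scatter). Another report at the limit of this assay remains a real possibility. The estimate for compound 3 is 33000 nM, with an expected range of 14000 nM to 50000 nM.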

Compound 3, half-maximal inhibitory concentration: > 50000 nM
Compound 3 was reported as a limit; the forecaster's own chance of this, stated with the estimate: 35%; at least 1.5-fold (0.18 log units) between middle value and limit.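

In this assay, cyano in place of carbamoyl on this aromatic carbon, para to a methoxy group, leaves the series at its limit, so the step between compound 2 and compound 3 cannot be read and the change has no measurable size here. Methoxy in place of hydrogen on an aromatic carbon gives an at least 1.1-fold higher number from compound 1 to compound 3 (0.04 log units; that floor lies within the scatter), so this comparison does not show the methoxy group shifting the read-out beyond the scatter. Both substituents at this position therefore remain unranked, and the series offers little readable range: the limit of > 50000 nM in this assay, at which 2 of the 3 values shown sit.

On these data alone, it remains open whether an amine or a carboxylic acid on this aromatic carbon would give a number rather than a limit. As far as these compounds go, whether carbamoyl and cyano differ at all also stays open.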